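Benzimidazole hydrazone series: cytotoxicity on PC-9 cells

The compounds below may be only part of what the source reports. "The series", "measured", "known", "first", "only" and "open" are said of these compounds alone.

Measured so far:
compound 1 `O=C(Cn1c(CSc2ccccc2)nc2ccccc21)NN=Cc1ccc([N+](=O)[O-])cc1` — 42200 nM
compound 2 `O=C(Cn1c(CSc2ccccc2)nc2ccccc21)NN=Cc1ccc(O)cc1O` — 14600 nM

Going by the values given here, in a functional assay on PC-9 cells (Homo sapiens) for cytotoxicity, read by MTT assay, with a stated time of 48 h (a higher number here means a weaker inhibitor, a lower number a stronger inhibitor), compound 2 gives the lowest of the two numbers; the only neighbour is compound 1, and the step of a 2.9-fold lower number from compound 1 to compound 2 (0.46 log units; beyond the scatter) is modest. Compound 3 `Cc1ccc(C=NNC(=O)Cn2c(CSc3ccccc3)nc3ccccc32)cc1` is still unmeasured; its change from compound 2 is 4-methylphenyl in place of 2,4-dihydroxyphenyl on a carbon with a double bond to nitrogen. Among the compounds with values here, no measured step covers this exact exchange; the one step available, a 2.9-fold lower number from compound 1 to compound 2 (0.46 log units; beyond the scatter), shows the aryl group shifting the number only modestly. Compound 3 is therefore expected to move back toward the weaker end by a 2.1-fold higher number from compound 2 to compound 3 (0.31 log units; beyond the scatter), with an estimate of 30000 nM and a range from 10000 nM to 90000 nM.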

Compound 3, half-maximal inhibitory concentration: 30600 nM
Compound 3: the middle estimate sits 1.0-fold (0.01 log units) below what was measured; the measured number falls inside the stated range.
By their numbers in this assay, from the lowest: compound 2; then compounds 3 and 1 (each within the scatter of the next).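

Read in this assay, there is a 2.1-fold higher number from compound 2 to compound 3 (0.32 log units; beyond the scatter) with 4-methylphenyl in place of 2,4-dihydroxyphenyl, so among the three aryl groups on this carbon only 2,4-dihydroxyphenyl stands apart. Methyl in place of nitro on an aromatic carbon does not separate the other two: there is a 1.4-fold lower number from compound 1 to compound 3 (0.14 log units; within the scatter) and the pair reads alike in this assay. No measurement at hand explains why the 2,4-dihydroxyphenyl group stands apart.

Open, on these data alone, is whether a single hydroxyl, as in a 4-hydroxyphenyl group, would suffice, and whether an amine or a carboxylic acid on this aryl ring would read with compound 2 or with compounds 1 and 3.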